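The compounds below may be only part of what the source reports. "The series", "measured", "known", "first", "only" and "open" are said of these compounds alone.

Compound 1, `COc1cc(N(C)C(=O)c2ccc([N+](=O)[O-])cc2)cc(OC)c1OC`, was tested in a functional assay on Daoy cells (Homo sapiens) for cytotoxicity, read by MTT assay, with a stated time of 72 h; on this read-out higher numbers stand for weaker inhibition and lower numbers for stronger inhibition. In this assay compound 1 gives >= 125000 nM, which is a limit of the assay rather than a number. A second compound, compound 2, `COc1ccc(C(=O)N(C)c2cc(OC)c(OC)c(OC)c2)cc1`, carries a methoxy in place of the nitro on an aromatic carbon. In this assay compound 2 gives >= 125000 nM, again a limit. Among the compounds with values here, the step that the two limits leave unreadable from compound 1 to compound 2 is therefore unreadable, and the only evidence here is the limit of >= 125000 nM in this assay, at which 2 of the 2 values shown sit. Compound 3, `COc1cc(NC(=O)c2ccc([N+](=O)[O-])cc2)cc(OC)c1OC`, differs from compound 1 by hydrogen in place of methyl on an amide-type nitrogen. Within the data shown here, no measured step touches the amide nitrogen, so nothing measured gives the size or direction of this change. Both measured values sit at the limit recorded in the limit of >= 125000 nM in this assay, at which 2 of the 2 values shown sit, and on that basis compound 3 is expected to stay near it. The change from compound 1 is estimated as an at least 1.1-fold lower number from compound 1 to compound 3 (0.05 log units; that floor lies within the scatter), within the scatter. The estimate for compound 3 is 110000 nM, ranging from 25000 nM to 250000 nM.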

Compound 3, half-maximal inhibitory concentration: 52900 nM
Compound 3: the middle estimate sits 2.1-fold (0.32 log units) above what was measured; the measured number falls inside the stated range.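

In this assay, within the data shown here, replacing the methyl on the amide-type nitrogen with hydrogen yields the first real number in this set, and the change is an at least 2.3-fold lower number from compound 1 to compound 3 (0.37 log units; beyond the scatter). This size is only a floor, as the starting value is a limit, so the true gap could be larger. The nitrogen is therefore a place where a small change moves the read-out beyond the scatter, something the earlier swap of nitro for methoxy could not show, as that step cannot be read: the limit of >= 125000 nM in this assay, at which 2 of the 3 values shown sit.

As far as these compounds go, only methyl and hydrogen are seen on this nitrogen, so it remains open how an ethyl group or a longer chain there would behave. Also open, from the compounds shown here alone, is whether the amide hydrogen would give a similar step with methoxy in place of the nitro, or how an amine at that place would compare.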